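Benzoyl variant of compound 1 in the cytotoxicity series

The compounds below may be only part of what the source reports. "The series", "measured", "known", "first", "only" and "open" are said of these compounds alone.

Compound 1 `Cc1ccc(-c2nn(-c3ccccc3)cc2-c2nc3ccccc3n2C(=O)c2ccc(C)nc2)cc1` is assessed in an ADME assay on HEK-293T cells (Homo sapiens) for cytotoxicity, read by MTT assay, with a stated time of 24 h (on this read-out lower numbers stand for higher toxicity in this test and higher numbers for lower toxicity in this test), where compound 1 gives 145000 nM. Among the three measured compounds it holds the second highest number; compound 2 `Cc1ccc(C(=O)n2c(-c3cn(-c4ccccc4)nc3-c3ccc(C(F)(F)F)cc3)nc3ccccc32)cn1` gives 153000 nM and compound 3 `O=C(c1ccncc1)n1c(-c2cn(-c3ccccc3)nc2-c2ccc(C(F)(F)F)cc2)nc2ccccc21` gives 135000 nM, and both stand within the scatter of compound 1. The step of a 1.1-fold higher number from compound 1 to compound 2 (0.02 log units; within the scatter) and the step of a 1.1-fold lower number from compound 2 to compound 3 (0.05 log units; within the scatter) are each within the scatter, so no change beyond the scatter has yet been seen in this set.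

Compound 4 `Cc1ccc(-c2nn(-c3ccccc3)cc2-c2nc3ccccc3n2C(=O)c2ccccc2)cc1` differs from compound 1 by phenyl in place of 6-methylpyridin-3-yl on a carbonyl carbon. The step that bears most directly on it is a 1.1-fold lower number from compound 2 to compound 3 (0.05 log units; within the scatter), which also alters the group on the carbonyl carbon and moved the number no further than the scatter; the step of a 1.1-fold higher number from compound 1 to compound 2 (0.02 log units; within the scatter) at a different place was likewise flat. For compound 4 no step beyond the scatter is therefore expected in this assay, in either direction. Compound 4 is accordingly expected to give 145000 nM, within a range of 80000 nM to 260000 nM. The estimate means no change at the digits printed from compound 1 to compound 4 (within the scatter), expected to lie within the scatter.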

Compound 4, half-maximal cytotoxic concentration: 204000 nM
Beside the measured number, compound 4's estimate is 1.4-fold (0.15 log units) below it; the measured number falls inside the stated range.
By their numbers in this assay, from the lowest: compounds 3, 1, 2 and 4 (each within the scatter of the next).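

With the benzoyl group on the carbonyl carbon, the aromatic ring no longer carries a hetero atom, a hydrogen-bond acceptor or a methyl group, yet in this assay the result is a 1.4-fold higher number from compound 1 to compound 4 (0.15 log units; within the scatter). The earlier change at this position, a 1.1-fold lower number from compound 2 to compound 3 (0.05 log units; within the scatter), only exchanged one pyridine-type group for another, so it did not test a ring of carbon only; the new pair shows that, on the core of compound 1, neither the ring nitrogen nor the methyl group of 6-methylpyridin-3-yl is needed to keep the number within the scatter in this test. No measurement at hand accounts for the size of this step.

On these data alone, all the groups on the carbonyl carbon so far are six-membered aromatic rings, so it remains open whether a non-aromatic group there, such as cyclohexyl, a short alkyl chain or morpholine, would give a step beyond the scatter. For the compounds shown here, also open is whether a phenyl ring bearing a carboxylic acid or an amine would move the number in this assay, and no step yet defines a change that does.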